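Changing the aryl group on the amide of compound 1

This account rests on a few compounds, and the source may have more. Where it says the series, first, only, none or still open, it means among the compounds named here.

Three compounds have been measured in a functional assay on L1210 cells (Mus musculus) for cytotoxicity; a lower number here means a stronger inhibitor, a higher number a weaker inhibitor:
compound 1 `O=C(/C=C/C(=O)N1C/C(=C\c2ccccc2)C(=O)/C(=C/c2ccccc2)C1)Nc1ccc(Cl)c(Cl)c1`: 7500 nM
compound 2 `O=C(/C=C/C(=O)N1C/C(=C\c2ccc([N+](=O)[O-])cc2)C(=O)/C(=C/c2ccc([N+](=O)[O-])cc2)C1)Nc1ccc(Cl)c(Cl)c1`: 1700 nM
compound 3 `CC(=O)c1ccc(NC(=O)/C=C/C(=O)N2C/C(=C\c3ccc([N+](=O)[O-])cc3)C(=O)/C(=C/c3ccc([N+](=O)[O-])cc3)C2)cc1`: 1400 nM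

Among these, compound 1 stands highest, and its gaps to compound 2 and to compound 3 both lie beyond the scatter. The step to compound 4 `Cc1ccc(NC(=O)/C=C/C(=O)N2C/C(=C\c3ccccc3)C(=O)/C(=C/c3ccccc3)C2)cc1` changes (4-methylphenyl in place of 3,4-dichlorophenyl on an amide-type nitrogen). Among the measured compounds shown here, one measured step touches the same position: a 1.2-fold lower number from compound 2 to compound 3 (0.08 log units; within the scatter). That exchange of the aryl group on the amide nitrogen left the number within the scatter, so a similarly small step is expected here, with no clear direction. Compound 4 is therefore expected near 6500 nM, with a range from 2500 nM to 16000 nM. That estimate means a 1.2-fold lower number from compound 1 to compound 4 (0.06 log units; within the scatter), a step not expected to exceed the scatter.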

Compound 4, half-maximal inhibitory concentration: 5800 nM
The estimate for compound 4 lay 1.1-fold (0.05 log units) above the measured number, and the stated range covers the measured number.
By their numbers in this assay, from the lowest: compounds 3 and 2 (each within the scatter of the next); then compounds 4 and 1 (each within the scatter of the next).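

In this assay the amide aryl exchange gives a 1.3-fold lower number from compound 1 to compound 4 (0.11 log units; within the scatter) and so extends the earlier finding to a second core. Both aryl exchanges shown, one on the core of compound 1 and one on the core of compound 2, stay within the scatter, even though this one removes both chlorines and adds a methyl. No measurement here accounts for this.

From the compounds shown here alone, it remains open whether an aryl group carrying an amine or a carboxylic acid, or a longer chain in place of the aryl group, would shift the number beyond the scatter.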